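The source may hold more compounds than are shown below. What is called first, only, known or untested is meant among the compounds shown, and "the series" means these compounds.

Three compounds from one series have been run in a functional assay on MDA-MB-435 cells (Homo sapiens) for cytotoxicity, read by MTT assay, with a stated time of 72 h; a higher number here means a weaker inhibitor, a lower number a stronger inhibitor. Compound 1 `C[C@@H](CO)Nc1nc(C(=O)NCc2ccc(F)cc2)c(O)c2ncccc12` returns only a limit of the assay, > 20000 nM. Compound 2 `C[C@@H](Nc1c(C(=O)NCc2ccc(F)cc2)nc(Br)c2cccnc12)c1ccccc1` also returns only a limit, > 20000 nM. Going by the values given here, compound 3 `N[C@H]1CC[C@H](Nc2c(C(=O)NCc3ccccn3)nc(Br)c3cccnc23)CC1` is the single compound with a measured number, giving 4000 nM, and so it is the only point of reference among the three. Compound 4 `COc1ccc(CNC(=O)c2nc(Br)c3cccnc3c2N[C@H]2CC[C@H](N)CC2)cc1` differs from compound 3 in one place: 4-methoxyphenyl in place of pyridin-2-yl on a saturated chain carbon bound to an amide-type nitrogen. Among the compounds with values here, no measured pair shows this same change, so its effect has not been seen directly. In this assay the step is expected to be no change at the digits printed from compound 3 to compound 4 (within the scatter), a shift no larger than the usual scatter, in no firm direction. Compound 4 is therefore estimated at 4000 nM, with a range from 1500 nM to 12000 nM.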

Compound 4, half-maximal inhibitory concentration: 5000 nM
Beside the measured number, compound 4's estimate is 1.3-fold (0.10 log units) below it; the range from low to high includes it.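

In this assay, going by these compounds alone, the first step that can be read at this position, on a saturated chain carbon bound to an amide-type nitrogen, is a 1.3-fold higher number from compound 3 to compound 4 (0.10 log units; within the scatter). On this evidence, 4-methoxyphenyl and pyridin-2-yl cannot be told apart here, whether the six-membered aromatic ring is of carbon only or holds a hetero atom. Going by these compounds, whether an amine or a carboxylic acid on that ring, or a longer chain leading to it, would move the number remains open. The other compounds offer no further step to read, as their values are limits: the limit of > 20000 nM in this assay, at which 2 of the 4 values shown sit.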